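Swapping a saturated ring back for a flat aromatic one

This account rests on a few compounds, and the source may have more. Where it says the series, first, only, none or still open, it means among the compounds named here.

Compound 2 `Cc1nc(N)sc1CCCNC(=N)NC(=O)C[C@H](C)C1CCCCC1` gives 78% in a functional assay on cardiac atrium for agonist activity at histamine H2 receptor (Cavia porcellus); a lower number here means a smaller maximal response, a higher number a larger maximal response. It stands second highest of the three measured numbers: compound 1 `Cc1nc(N)sc1CCCNC(=N)NC(=O)C[C@@H](C)c1ccccc1` gives 73%, within the scatter of it, while compound 3 `C[C@H](CC(=O)NC(=N)NCCCc1c[nH]cn1)c1ccccc1` gives 93%, beyond the scatter. Compound 4 `Cc1nc(N)sc1CCCNC(=N)NC(=O)CC(C)c1ccccc1` differs from compound 2 by 1-phenylethyl in place of 1-cyclohexylethyl on a saturated chain carbon bound to a carbonyl carbon. The step that bears on this is the reverse of the measured one, a number 5 percentage points higher from compound 1 to compound 2 (within the scatter), which was within the scatter; the other step, a number 20 percentage points higher from compound 1 to compound 3 (beyond the scatter), changes a different part of the molecule and is not relevant. Compound 4 is therefore expected to give a maximal response close to compound 1, estimated at 73% with a range of 62% to 84%, a step of a number 5 percentage points lower from compound 2 to compound 4 (within the scatter) that should stay within the scatter.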

Compound 4, largest response reached (Emax), in percent of the reference or control that the assay uses: 89%
The estimate for compound 4 lay 16 percentage points below the measured number; measured number above the stated range.
By their numbers in this assay, from the lowest: compounds 1 and 2 (each within the scatter of the next); then compounds 4 and 3 (each within the scatter of the next).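

In this assay, 1-phenylethyl in place of 1-cyclohexylethyl gives a number 11 percentage points higher from compound 2 to compound 4 (beyond the scatter) at this position. The aromatic ring alone does not decide the response, however, since the same group also gives a number 16 percentage points higher from compound 1 to compound 4 (beyond the scatter) here. The only thing separating that last pair is a matter of stereochemistry: the fact that one of compounds 1 and 4 is drawn with a defined configuration and the other without, at the place where they differ

As far as these compounds go, whether compound 4 holds one configuration or a mixture of both stays open. So does how a benzyl or 1-cyclopentylethyl group would behave on this saturated chain carbon.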